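This account rests on a few compounds, and the source may have more. Where it says the series, first, only, none or still open, it means among the compounds named here.

Working notes on the series in an ADME assay on MRC5 cells (Homo sapiens) for antiproliferative activity, read by MTT assay, with a stated time of 48 h; a higher number here means a weaker inhibitor, a lower number a stronger inhibitor.

Compound 1 `Cc1oc2c3c(ccc2c(=O)c1C)OC[C@H]1[C@@H]3C2=C(CCCC2=O)OC1(C)C` and compound 2 `Cc1oc2c3c(ccc2c(=O)c1-c1ccccc1)OC[C@H]1[C@@H]3C2=C(CCCC2=O)OC1(C)C` share one core. Compound 3 `Cc1nn(-c2ccccc2)c2c1[C@@H]1c3c(ccc4c(=O)c(C)c(C)oc34)OC[C@@H]1C(C)(C)O2` and the unmeasured compound 4 `Cc1nn(-c2ccccc2)c2c1[C@@H]1c3c(ccc4c(=O)c(-c5ccccc5)c(C)oc34)OC[C@@H]1C(C)(C)O2` share another, and the difference between the two cores is not broken down here.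

In this assay compound 1 gives only a limit of the assay, > 100000 nM. In the same assay compound 2 also gives only a limit, > 100000 nM. Compound 3 likewise gives only a limit, > 100000 nM.

The change from compound 1 to compound 2 is phenyl in place of methyl on an aromatic carbon. The step it makes in this assay is a step that the two limits leave unreadable from compound 1 to compound 2 because the limit of > 100000 nM in this assay, at which 3 of the 3 values shown sit, is where both values sit, so no size can be read from it.

The same change is made from compound 3 to compound 4: phenyl in place of methyl on an aromatic carbon. The place of the change is the same in words for both pairs, so it is the same change on a different core.

The step from compound 3 to compound 4 in this assay is expected to be a step that the limit leaves unreadable from compound 3 to compound 4, an expectation that rests on the unreadable step from compound 1 to compound 2 and on (the limit of > 100000 nM in this assay, at which 3 of the 3 values shown sit), at which every measured value of the series sits.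

Compound 4 is therefore expected to give about 150000 nM in this assay, most likely reported as a limit once more, with an expected range from 60000 nM to 500000 nM.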

Compound 4, half-maximal inhibitory concentration: > 100000 nM
Compound 4 was reported as a limit (the forecaster's own chance of this, stated with the estimate: 90%); the middle value lies beyond the limit too.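

No new step can be read from compound 3 to compound 4 in this assay, because both compounds give only a limit of the assay: the limit of > 100000 nM in this assay, at which 4 of the 4 values shown sit.

The compounds shown leave open whether phenyl in place of methyl on an aromatic carbon has any effect on either core, and how the two cores compare, with no compound giving a value other than a limit.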